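Methoxycarbonyl in place of ethoxycarbonyl on the shared core

The source may report more compounds than this note shows. Statements on the series, on what has been measured and on what is new or still open speak of the compounds shown alone.

Measured compounds:
- compound 1, `CCOC(=O)C1=C(C)NC2=C(C(=O)C(C)(C)CC2)C1c1cc([N+](=O)[O-])ccc1O`: 70%
- compound 2, `CC1=C(C(=O)OCC(C)C)C(c2cc(Br)cc([N+](=O)[O-])c2O)C2=C(CCC(C)(C)C2=O)N1`: 10%

In an assay for inhibition of Voltage-dependent L-type calcium channel subunit alpha-1C (Rattus norvegicus), read by patch clamp, tested at 10 uM (on this read-out higher numbers stand for more inhibition at the one concentration tested (going by the name of the read-out) and lower numbers for less inhibition), compound 1 gives 70%, the higher of the two numbers recorded. Compound 2 gives 10% in this assay, and the gap between the two values lies beyond the scatter. Compound 2 differs from compound 1 in more than one place, so the two values are noted side by side and nothing further is drawn from the pair.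

Compound 3, `COC(=O)C1=C(C)NC2=C(C(=O)C(C)(C)CC2)C1c1cc([N+](=O)[O-])ccc1O`, is not yet measured. It differs from compound 1 in one place: hydrogen in place of methyl on a saturated chain carbon bound to an oxygen next to a carbonyl group. Read one bond further out, the change is ethoxycarbonyl to methoxycarbonyl, leaving the rest of the shared core and the substituted ring untouched.

Going by the values given here, no step between measured compounds of this kind is available, so there is nothing to size the change against. The expectation is a step no larger than the scatter, in either direction, that is a number 5 percentage points lower from compound 1 to compound 3 (within the scatter) as the estimated shift. On that basis compound 3 is expected to give about 65% in this assay, with a likely range from 45% to 85%.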

Compound 3, a percentage reported as inhibition, at one concentration (the size of the read-out at that concentration, not a potency): < 30%
Compound 3 gave a limit, no number (the forecaster's own chance of this, stated with the estimate: 0%); middle value at least 35 percentage points from the limit.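

In this assay, going by these compounds alone, hydrogen in place of methyl on a saturated chain carbon bound to an oxygen next to a carbonyl group is the first change that can be read in one place, and it amounts to a number at least 40 percentage points lower from compound 1 to compound 3 (beyond the scatter). Within the data shown here, the earlier pair could not show this, as those two compounds differ in more than one place, so this position had no step of its own until now. Compound 3 is recorded as a limit and not as a number, so the step has a bound rather than an exact size, and the reading that bears on it is this one: the limit of < 30% in this assay, at which 1 of the 3 values shown sits.

Still open, from the compounds shown here alone, is whether a propoxycarbonyl group, a carboxylic acid or an amide at this place would give a value closer to that of compound 1 or to the limit of compound 3. Also open, going by these compounds, is whether the same change from ethoxycarbonyl to methoxycarbonyl would give a step of similar size on a differently substituted ring, since the value of compound 2, 10%, cannot be set against this position alone.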